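The source may report more compounds than this note shows. Statements on the series, on what has been measured and on what is new or still open speak of the compounds shown alone.

In a functional assay on HT-29 cells (Homo sapiens) for cytotoxicity, read by MTT assay, with a stated time of 24 h, tested at 1.6 ug/mL (on this read-out lower numbers stand for a weaker effect and higher numbers for a stronger effect at the one concentration tested), compound 1 `Cn1c(-c2ccc(NC(=O)CCl)cc2)nc(-c2ccccc2)c1-c1ccccc1` gives 14.4%; compound 2 `Cn1c(-c2ccc(NC(=O)CSc3nc4ccccc4o3)cc2)nc(-c2ccccc2)c1-c1ccccc1` gives 41%; compound 3 `Cn1c(-c2ccc(NC(=O)CSc3nc4cc(Cl)ccc4o3)cc2)nc(-c2ccccc2)c1-c1ccccc1` gives 17.4%.

Compound 2 holds the highest of the three numbers: a number 23.6 percentage points lower from compound 2 to compound 3 (beyond the scatter), and a number 26.6 percentage points higher from compound 1 to compound 2 (beyond the scatter). Compound 4 `Cc1nnc(SCC(=O)Nc2ccc(-c3nc(-c4ccccc4)c(-c4ccccc4)n3C)cc2)s1` differs from compound 2 in one place: 5-methyl-1,3,4-thiadiazol-2-yl in place of 1,3-benzoxazol-2-yl on a sulfur. Within the data shown here, no measured step exchanges one ring for another on that sulfur, so the bearing is indirect: the steps of a number 26.6 percentage points higher from compound 1 to compound 2 (beyond the scatter) and a number 23.6 percentage points lower from compound 2 to compound 3 (beyond the scatter) both show that this read-out answers modestly to what stands on the sulfur-bearing chain carbon. Compound 4 is therefore expected to fall below compound 2 by a modest step, a number 16 percentage points lower from compound 2 to compound 4 (beyond the scatter). The estimate for compound 4 is 25%, within a range from 10% to 42%.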

Compound 4, a percentage reported as activity, at one concentration (the size of the read-out at that concentration, not a potency): 39.9%
Compound 4: middle estimate off by 14.9 percentage points, on the low side; the range from low to high includes it.
By their numbers in this assay, from the lowest: compounds 1 and 3 (each within the scatter of the next); then compounds 4 and 2 (each within the scatter of the next).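

In this assay, the sulfur accepts a change of ring with no readable effect: a number 1.1 percentage points lower from compound 2 to compound 4 (within the scatter), even though the entering group lacks the six-membered aromatic ring. The rise over the chloro compound also holds with this second ring, a number 25.5 percentage points higher from compound 1 to compound 4 (beyond the scatter), and a number 22.5 percentage points higher from compound 3 to compound 4 (beyond the scatter), so the low number of compound 3 does not extend to every ring on that sulfur. No evidence is available to explain why these two rings read alike.

Still open, going by these compounds, is whether any aromatic ring is needed there, or whether a simple amine or a carboxylic acid on the chain would serve as well.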